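Adding a methoxy group to a weak cytotoxic scaffold

This account rests on a few compounds, and the source may have more. Where it says the series, first, only, none or still open, it means among the compounds named here.

Three compounds sharing one core were tested in a functional assay on HL-60 cells (Homo sapiens) for cytotoxicity, read by CCK-8 assay, with a stated time of 72 h; a lower number here means a stronger inhibitor, a higher number a weaker inhibitor. Compound 1, with the structure `C=CCn1c(=O)/c(=C\c2ccc(Cl)c(Cl)c2)[nH]c(=O)/c1=C\c1ccccc1`, returned no number at all: in this assay compound 1 is recorded as "not active" (no number reported). Compound 2, with the structure `C=CCn1c(=O)/c(=C\c2cccc(Br)c2)[nH]c(=O)/c1=C\c1cccc(Br)c1`, is the second entry of this kind; in this assay compound 2 is also given as "not active" (no number reported). Only compound 3, with the structure `COc1ccccc1/C=c1/[nH]c(=O)/c(=C\c2ccccc2OC)n(C)c1=O`, carries a measured value: in this assay compound 3 gives 16200 nM, a weak result. So compound 1 stands among the entries without a single number, with one further compound beside it in the same position.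

The next compound to be measured is compound 4, with the structure `C=CCn1c(=O)/c(=C\c2ccc(Cl)c(Cl)c2)[nH]c(=O)/c1=C\c1ccccc1OC`. It differs from compound 1 in one place: methoxy in place of hydrogen on an aromatic carbon. The change is methoxy in place of hydrogen, sitting on an aromatic carbon of a six-membered aromatic ring of carbon only, so that the phenyl ring of compound 1 becomes a 2-methoxyphenyl ring. Among the measured compounds shown here, compound 3 shows that a core bearing methoxyphenyl rings can give a weak, countable value, and no measured step between two compounds tells how large the move from compound 1 is expected to be. Because compound 3 gives 16200 nM, the value of compound 4 is expected to be weak as well, estimated at 20000 nM, within a range from 5000 nM to 80000 nM.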

Compound 4, half-maximal inhibitory concentration: "not active" (no number reported)
For compound 4 the study gives words and no number, and the estimate cannot be compared.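

Compound 1 and compound 4 are both recorded as not active, without a number, so no step can be read from the change of hydrogen to methoxy. No measurement shown here accounts for this result. The compounds shown leave open whether this change alters cytotoxicity at all on the shared core.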